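Carbamate in place of amide on a low-permeability series

The source may report more compounds than this note shows. Statements on the series, on what has been measured and on what is new or still open speak of the compounds shown alone.

Of the compounds shown here, three sharing one core have been measured in an ADME assay on Caco-2 cells (Homo sapiens) for permeability, in the apical to basolateral direction; a higher number here means that the compound crosses the layer faster, a lower number that the compound crosses the layer more slowly. Compound 1 `Cn1cncc1CN1CC(N(CC2CCN(C(=O)c3ccccc3)CC2)S(=O)(=O)c2ccccn2)Cc2cc(C#N)ccc21` gives 0.5 10^-6 cm/s. Compound 2 `Cn1cncc1CN1CC(N(CC2CCN(C(=O)CC(C)(C)C)CC2)S(=O)(=O)c2ccccn2)Cc2cc(C#N)ccc21` gives 0.5 10^-6 cm/s, level with compound 1 at the digits shown, and the step of no change at the digits printed from compound 1 to compound 2 (within the scatter) lies within the scatter. Compound 3 `Cn1cncc1CN1CC(N(CC2CCN(S(C)(=O)=O)CC2)S(=O)(=O)c2ccccn2)Cc2cc(C#N)ccc21` gives 0.1 10^-6 cm/s, the lowest of the three numbers, and the steps of a 5.0-fold lower number from compound 1 to compound 3 (0.70 log units; beyond the scatter) and a 5.0-fold lower number from compound 2 to compound 3 (0.70 log units; beyond the scatter) both lie beyond the scatter.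

Compound 4 `CC(C)OC(=O)N1CCC(CN(C2Cc3cc(C#N)ccc3N(Cc3cncn3C)C2)S(=O)(=O)c2ccccn2)CC1` is not yet measured. It differs from compound 2 in one place: isopropoxy in place of neopentyl on a carbonyl carbon. Going by the values given here, two measured steps bear on this. The exchange of one carbonyl substituent for another, no change at the digits printed from compound 1 to compound 2 (within the scatter), left the number unchanged, whereas the replacement of the whole carbonyl group by methylsulfonyl, a 5.0-fold lower number from compound 2 to compound 3 (0.70 log units; beyond the scatter), lowered it modestly. Compound 4 keeps the carbonyl and changes only what sits on it, so the step to compound 4 is expected to resemble the former case rather than the latter.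

The expected step is therefore a 1.3-fold lower number from compound 2 to compound 4 (0.10 log units; within the scatter), that is, no shift beyond the scatter. Compound 4 is estimated at 0.4 10^-6 cm/s, with a range from 0.15 10^-6 cm/s to 1 10^-6 cm/s.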

Compound 4, apparent permeability: 1 10^-6 cm/s
Compound 4: middle estimate off by 2.5-fold (0.40 log units), on the low side; low and high end bracket the measured number.
By their numbers in this assay, from the lowest: compound 3; then compounds 1, 2 and 4 (each within the scatter of the next).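

Across the three carbonyl compounds, the group on the carbonyl carbon can now be phenyl, neopentyl or isopropoxy without a step beyond the scatter in this assay, even though isopropoxy brings an oxygen and a hydrogen-bond acceptor that neopentyl lacks (a 2.0-fold higher number from compound 2 to compound 4 (0.30 log units; within the scatter); a 2.0-fold higher number from compound 1 to compound 4 (0.30 log units; within the scatter)). Compound 4 also gives the largest step yet measured against the methylsulfonyl compound (a 10-fold higher number from compound 3 to compound 4 (1.00 log units; beyond the scatter)), so among these four compounds, compounds 1, 2 and 4 remain together, and compound 3 alone stands apart from them. No measurement at hand offers an explanation for either observation.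

The compounds shown leave open whether an amine on the carbonyl carbon, giving a urea, or a smaller alkoxy group such as methoxy would stay with compounds 1, 2 and 4 or fall away from them. They also leave open whether the separation of compound 3 belongs to the sulfonyl link in general or to its methyl group, a question that an ethylsulfonyl or phenylsulfonyl group on the same ring nitrogen would address.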